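The compounds below may be only part of what the source reports. "The series", "measured", "known", "first", "only" and "open" are said of these compounds alone.

Series notes, antiproliferative read-out.

Compound 1 `COc1cccc(S(=O)(=O)N2CCC(N3CCC(C)CC3)CC2)c1` carries a 3-methoxyphenyl on the sulfonyl sulfur. In a functional assay on DLD-1 cells (Homo sapiens) for antiproliferative activity, read by CellTiter-Glo, with a stated time of 72 h (on this read-out higher numbers stand for weaker inhibition and lower numbers for stronger inhibition), compound 1 reaches only the limit of the assay, > 5000 nM, and no number is obtained. Compound 2 `CCc1ccc(S(=O)(=O)N2CCC(N3CCC(C)CC3)CC2)cc1` carries a 4-ethylphenyl on the same sulfonyl sulfur. In this assay compound 2 likewise stops at the limit, > 5000 nM, again with no number. The step that the two limits leave unreadable from compound 1 to compound 2 therefore cannot be read in either direction. Both values shown sit at the limit of > 5000 nM in this assay, at which 2 of the 2 values shown sit, so compound 2 stands at the limit, with no measured value in the series to rank it against.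

Compound 3 `CC1CCN(C2CCN(S(=O)(=O)c3cncc(Br)c3)CC2)CC1` has not been measured. It differs from compound 2 by 5-bromopyridin-3-yl in place of 4-ethylphenyl on a sulfonyl sulfur. Only the unreadable step from compound 1 to compound 2 concerns the group on the sulfonyl sulfur, and it gives no size and no direction. With both measured compounds at the limit, the step that the limit leaves unreadable from compound 2 to compound 3 is expected to leave compound 3 at or near the same limit, and a reported limit rather than a number is the most likely outcome. For compound 3 in this assay the estimate is 7000 nM, within 1500 nM to 30000 nM.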

Compound 3, half-maximal inhibitory concentration: > 5000 nM
Compound 3: a limit, no number; the forecaster's own chance of this, stated with the estimate: 75%; the middle value does not contradict the limit.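

The steps from compound 1 and from compound 2 to compound 3 cannot be read in this assay because all three compounds stop at a limit and give no number: the limit of > 5000 nM in this assay, at which 3 of the 3 values shown sit. The compounds shown leave open whether any group on the sulfonyl sulfur gives a measurable value on the shared core, and how these three groups rank.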